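A few compounds are considered here, and "the series" means these few. Any claim that something is new, unique, unknown or untested is made for them only; others in the source may bear on it.

Three compounds share one core and differ only in the groups hung on it. Compound 1 `CCOC(=O)CSc1nnc(COc2ccccc2C2=NOC(c3ccc(Cl)cc3Cl)C2)n1NC(=O)c1ccccc1` has in an ADME assay (MDM cells, Homo sapiens) for cytotoxicity, read by resazurin assay, with a stated time of 3 days (a higher number here means a weaker inhibitor, a lower number a stronger inhibitor), only the entry "not determined" (no result reported) and no number. Within the data shown here, compound 2 `CCCCSc1nnc(COc2ccccc2C2=NOC(c3ccc(Cl)cc3Cl)C2)n1NC(C)=O` is the only one with a number: in this assay compound 2 gives 2.6 ug/mL, and with nothing else measured it has no neighbour to be compared against. Compound 3 `CCCCSc1nnc(COc2ccccc2C2=NOC(c3ccc(Cl)cc3Cl)C2)n1NC(=O)c1ccccc1` differs from compound 2 in one place: phenyl in place of methyl on a carbonyl carbon. Among the measured compounds shown here, no measured pair shows what swapping acetyl for benzoyl does in this setting, so any expectation rests on compound 2 alone and on the fact that the rest of the molecule is unchanged. The expected step in this assay is a 1.3-fold lower number from compound 2 to compound 3 (0.11 log units; within the scatter), small and of uncertain direction, probably no larger than the scatter between repeat measurements. Compound 3 is therefore expected to give about 2 ug/mL in this assay, within a range from 0.7 ug/mL to 6 ug/mL.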

Compound 3, half-maximal inhibitory concentration: 2.5 ug/mL
The estimate for compound 3 lay 1.3-fold (0.10 log units) below the measured number, within the range that was stated.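

In this assay, among these compounds, the first measured pair at this position gives a 1.0-fold lower number from compound 2 to compound 3 (0.02 log units; within the scatter). An aromatic ring can therefore take the place of methyl on this carbonyl carbon with no difference beyond the usual scatter of the read-out, so acetyl and benzoyl cannot be told apart here while the rest of the molecule stays the same. No measurement is available that would explain this result.

Among the compounds shown here, compound 1 has no number, so no step involving it can be read. This single pair also leaves open whether the reading would hold with a different group in place of the phenyl, such as a longer alkyl chain, an amine or a carboxylic acid.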